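Cyanophenyl in Place of Dichlorophenyl on the Sulfonyl

The source may hold more compounds than are shown below. What is called first, only, known or untested is meant among the compounds shown, and "the series" means these compounds.

Measured compounds:
compound 1 `CC1CCN(c2c(S(=O)(=O)c3cc(Cl)cc(Cl)c3)cnc3c(F)cccc23)CC1`: 82%
compound 2 `CC1CCN(c2c(S(=O)(=O)c3ccc(F)cc3)cnc3cc(Cl)ccc23)CC1`: 91%
compound 3 `Cc1ccc(S(=O)(=O)c2cnc3ccc(C)cc3c2N2CCC(C)CC2)cc1`: 82%

In an assay on isolated protein for displacement of a labelled ligand from metabotropic glutamate receptor 5 (Homo sapiens), with a stated time of 60 min, tested at 1 uM (a lower number here means less inhibition, a higher number more inhibition at the concentration tested (going by the name of the read-out)), compound 1 gives 82%. Compound 3 gives 82%, level with compound 1 at the digits shown, and together these two are the lowest of the three numbers. Compound 2 gives 91%, a number a few points higher than compound 1, but that gap lies within the usual scatter of repeated measurements, so nothing separates the three compounds in this assay.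

Compound 4 `CC1CCN(c2c(S(=O)(=O)c3ccc(C#N)cc3)cnc3c(F)cccc23)CC1` differs from compound 1 in one place: 4-cyanophenyl in place of 3,5-dichlorophenyl on a sulfonyl sulfur. Within the data shown here, no pair of measured compounds differs in this place alone, so no measured step tells the size of this change. Compounds 2 and 3 carry other groups on the sulfonyl sulfur, yet they also differ from compound 1 in the shared core, so their values cannot be read as the effect of the sulfonyl group by itself. Given how closely all three measured numbers sit, the expected step is none beyond the scatter, in either direction.

For compound 4 the expected value is 80%, in a range from 62% to 92%, which means an expected step of a number 2 percentage points lower from compound 1 to compound 4 (within the scatter).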

Compound 4, a percentage reported as inhibition, at one concentration (the size of the read-out at that concentration, not a potency): 86%
Compound 4: the middle estimate sits 6 percentage points below what was measured; measured number inside the range.
By their numbers in this assay, from the lowest: compounds 1, 3, 4 and 2 (each within the scatter of the next).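

In this assay, among these compounds, placing 4-cyanophenyl instead of 3,5-dichlorophenyl on the sulfonyl sulfur gives a number 4 percentage points higher from compound 1 to compound 4 (within the scatter), and this is the first step where the group on the sulfonyl sulfur is the only thing that changes. The two aromatic rings at this position therefore show no separation in this read-out, even though the two chlorine atoms leave and a nitrile enters, bringing a hydrogen-bond acceptor that the dichlorophenyl group lacks. Nothing available here explains why the two groups read alike.

The steps from compounds 2 and 3 to compound 4 cannot be read, since those compounds differ from it in more than one place, and a percentage at a single concentration is not a potency, so compound 1 and compound 4 could still differ in a full concentration series. As far as these compounds go, it also remains open what number this assay would give for a phenyl ring bearing a carboxylic acid or an amine, or a saturated ring such as cyclohexyl, on the same sulfonyl sulfur.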